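The source may report more compounds than this note shows. Statements on the series, on what has been measured and on what is new or still open speak of the compounds shown alone.

Measured compounds in an in vitro ADME assay on microsomes from liver (Homo sapiens) for metabolic stability; on this read-out higher numbers stand for fast clearance and lower numbers for slow clearance:

Compound 1 `Cc1ccc2c(c1)c(Sc1ccc(Cl)cc1)c(C)n2CC(=O)O`: this assay reports only a limit, < 3 mL.min-1.g-1.
Compound 2 `Cc1c(Sc2ccc(Cl)cc2)c2c(-c3nccs3)cccc2n1CC(=O)O`: 43 mL.min-1.g-1.
Compound 3 `Cc1c(Sc2ccc(Cl)cc2)c2cc(-c3ccccc3)ccc2n1CC(=O)O`: 16 mL.min-1.g-1.

Compound 2 stands highest of the two numbers given in this assay; the nearest is compound 3, whose value of 16 mL.min-1.g-1 lies below it and beyond the scatter. For compound 1 only a limit is known; of the three values shown, one sits at the limit of < 3 mL.min-1.g-1 in this assay, at which 1 of the 3 values shown sits.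

Compound 4 `CNC(=O)c1cccc2c1c(Sc1ccc(Cl)cc1)c(C)n2CC(=O)O` differs from compound 2 in one place: methylcarbamoyl in place of 1,3-thiazol-2-yl on an aromatic carbon.

Within the data shown here, the only measured step that touches an aromatic carbon of the shared core is an at least 5.3-fold higher number from compound 1 to compound 3 (0.72 log units; beyond the scatter), where adding a phenyl raised clearance at least modestly. In compound 4 an aromatic ring leaves and methylcarbamoyl enters, so that step bears on it only by loose analogy. A step of modest size towards slower clearance is expected, a 2.9-fold lower number from compound 2 to compound 4 (0.46 log units; beyond the scatter), with wide uncertainty. Compound 4 is therefore estimated at 15 mL.min-1.g-1 in this assay, within 5 mL.min-1.g-1 to 40 mL.min-1.g-1.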

Compound 4, intrinsic clearance in microsomes: < 3 mL.min-1.g-1
Compound 4 was reported as a limit; the forecaster's own chance of this, stated with the estimate: 10%; middle value at least 5.0-fold (0.69 log units) from the limit.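

In this assay, the aromatic carbon ortho to a fused ring proves sensitive to its substituent: methylcarbamoyl in place of 1,3-thiazol-2-yl gives an at least 14-fold lower number from compound 2 to compound 4 (1.15 log units; beyond the scatter). The only earlier step, at a different aromatic carbon, ran towards faster clearance, so this is the first change shown to move the number down, and the high clearance of compound 2 is not fixed by the rest of the molecule. The value for compound 4 is a limit, so the step has a minimum size and no exact one: the limit of < 3 mL.min-1.g-1 in this assay, at which 2 of the 4 values shown sit.

The data leave open whether the loss of the aromatic ring or the arrival of the amide hydrogen matters more in this step. A dimethylcarbamoyl group or a phenyl on this same aromatic carbon would separate the two.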